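The source may hold more compounds than are shown below. What is called first, only, known or untested is meant among the compounds shown, and "the series" means these compounds.

Going by the values given here, compound 2 `COc1cc2cc(Oc3ccc(NC(=O)Nc4ccc(C)cc4)cc3)c(C)nc2cc1OC` gives 109% in a functional assay on SK-MEL-28 cells (Homo sapiens) for inhibition, read by sulforhodamine B assay, with a stated time of 48 h, tested at 10 uM (a lower number here means a stronger effect, a higher number a weaker effect of the compound at the concentration tested), the higher of the two numbers so far. Among the compounds with values here, compound 1 `COc1cc2cc(Oc3ccc(NC(=O)Nc4ccccc4)cc3)c(C)nc2cc1OC` gives 96.2% in this assay, and a number 12.8 percentage points higher from compound 1 to compound 2 (beyond the scatter) is the only step recorded. Compound 3 `COc1cc2cc(Oc3ccc(NC(=O)Nc4ccc(C(F)(F)F)cc4)cc3)c(C)nc2cc1OC` differs from compound 2 by trifluoromethyl in place of methyl on an aromatic carbon. Within the data shown here, no measured step exchanges one substituent for another at that place, so only a number 12.8 percentage points higher from compound 1 to compound 2 (beyond the scatter) bears on this change, and only loosely. Relative to compound 2, compound 3 is expected to show a step of about a number 7 percentage points lower from compound 2 to compound 3 (within the scatter) in this assay. The estimate for compound 3 is 102%, with a range from 85% to 118%.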

Compound 3, a percentage reported as activity, at one concentration (the size of the read-out at that concentration, not a potency): 58.4%
Compound 3: middle estimate off by 43.6 percentage points, on the high side; the whole stated range lies above it.
By their numbers in this assay, from the lowest: compound 3; then compound 1; then compound 2.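

In this assay, the aromatic carbon para to a large group tolerates change in both directions: a number 50.6 percentage points lower from compound 2 to compound 3 (beyond the scatter), and a number 37.8 percentage points lower from compound 1 to compound 3 (beyond the scatter), while methyl gave only a higher number than hydrogen. Among the groups shown, the identity of the substituent at this place therefore sets the direction of the step, and only trifluoromethyl gives a stronger effect than hydrogen. Nothing available accounts for the gap between trifluoromethyl and methyl.

On these data alone, whether a chlorine atom, a methoxy group or an amine at this place would track trifluoromethyl or methyl remains open. As far as these compounds go, the effect of trifluoromethyl elsewhere on this ring is also open.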